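From Fluoro to Dimethylamino on the Shared Core

The compounds below may be only part of what the source reports. "The series", "measured", "known", "first", "only" and "open" are said of these compounds alone.

Of the compounds shown here, three sharing one core have been tested so far, and none has yet given a number. In a functional assay on the whole organism with Rattus norvegicus as the target (on this read-out lower numbers stand for an effect already at smaller amounts and higher numbers for an effect only at larger amounts of compound), compound 1 `CCOC(=O)C(=O)Nc1nc(-c2ccc(F)cc2)cs1` gives > 10 mg/kg, which is a limit of the assay and not a number. Compound 2 `CCOC(=O)C(=O)Nc1nc(-c2cccc(O)c2)cs1` gives > 10 mg/kg, also a limit. Compound 3 `CCOC(=O)C(=O)Nc1nc(-c2ccccc2OC)cs1` gives > 30 mg/kg, again a limit. Compound 1 therefore stands at the limit of > 10 mg/kg in this assay, at which 2 of the 3 values shown sit, while the only other limit is the limit of > 30 mg/kg in this assay, at which 1 of the 3 values shown sits.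

Compound 4 `CCOC(=O)C(=O)Nc1nc(-c2ccc(N(C)C)cc2)cs1` has not yet been measured. It carries dimethylamino in place of fluoro on an aromatic carbon, para to a large group (dimethylamino in place of fluoro on an aromatic carbon). Among the compounds with values here, no measured pair differs in one place only, so the data offer no step from which to scale this change. The expected step that the limit leaves unreadable from compound 1 to compound 4 is none beyond the scatter, with no direction favoured. Compound 4 may well return only a limit too. As a number, compound 4 is estimated at 15 mg/kg, with an expected range from 4 mg/kg to 60 mg/kg.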

Compound 4, dose for half-maximal effect: about 1 mg/kg
Beside the measured number, compound 4's estimate is 15-fold (1.18 log units) above it; measured number outside the range, below it.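

The change from fluoro to dimethylamino, on an aromatic carbon para to a large group, gives in this assay an at least 10-fold lower number from compound 1 to compound 4 (1.00 log units; beyond the scatter), which shows that the result at this position depends strongly on the group it carries. Within the data shown here, compound 4 is the first compound on the shared core to give a number and not a limit, so the core itself does not rule out an effect at smaller amounts. Compound 1 itself remains at a limit of the assay, not a number: the limit of > 10 mg/kg in this assay, at which 2 of the 4 values shown sit.

The compounds shown give no reason for the step, and dimethylamino is the only amine among them. As far as these compounds go, whether a plain amino group or a larger diethylamino group at the same position would keep this effect remains open.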